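The source may report more compounds than this note shows. Statements on the series, on what has been measured and on what is new or still open speak of the compounds shown alone.

Compound 1, `Cc1ccc2nc(N(C)C)nc(NCc3ccc(C(=O)NC4CCN(Cc5ccc(F)cc5)CC4)cc3)c2c1`, in a functional assay on SW480 cells (Homo sapiens) for inhibition, read by luminescence and resazurin assay, with a stated time of 3 days (a lower number here means a stronger inhibitor, a higher number a weaker inhibitor), gives 1100 nM.
Compound 2, `CN(C)c1nc(NCc2ccc(C(=O)Nc3ccc(F)cc3)cc2)c2ccccc2n1`, in this assay gives 2600 nM.
Compound 3, `Cc1ccc2nc(N3CCNC(C)C3)nc(NCc3ccc(C(=O)NC4CCN(Cc5ccc(F)cc5)CC4)cc3)c2c1`, in this assay gives 1000 nM.

Compounds 1 and 3 share one core and differ in a single place: 3-methylpiperazin-1-yl in place of dimethylamino on an aromatic carbon. That exchange made a step of a 1.1-fold lower number from compound 1 to compound 3 (0.04 log units; within the scatter), so the two numbers cannot be told apart with confidence. Compound 2 has the highest number of the three, beyond the scatter against both compound 1 and compound 3; how its core differs from the core of compound 1 is not broken down here.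

Compound 4, `CC1CN(c2nc(NCc3ccc(C(=O)Nc4ccc(F)cc4)cc3)c3ccccc3n2)CCN1`, has not yet been measured. It stands to compound 2 as compound 3 stands to compound 1: the difference is 3-methylpiperazin-1-yl in place of dimethylamino on an aromatic carbon, and the surroundings of the place are described in the same words in both pairs, so this is the same change made a second time, now on the core of compound 2. Within the data shown here, the only guide to what it will do is the single earlier step, a 1.1-fold lower number from compound 1 to compound 3 (0.04 log units; within the scatter), which was small; there is no second example on the core of compound 2 to confirm that the change behaves alike there. On that basis the step from compound 2 to compound 4 in this assay is expected to be about a 1.1-fold lower number from compound 2 to compound 4 (0.03 log units; within the scatter), with a wide allowance for the core not being the same. Compound 4 is therefore estimated at 2400 nM, expected to lie between 1000 nM and 6000 nM.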

Compound 4, half-maximal inhibitory concentration: 3200 nM
Beside the measured number, compound 4's estimate is 1.3-fold (0.12 log units) below it; low and high end bracket the measured number.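

Made on the core of compound 2, the exchange of dimethylamino for 3-methylpiperazin-1-yl gave a step of a 1.2-fold higher number from compound 2 to compound 4 (0.09 log units; within the scatter) in this assay, so the numbers of these two compounds cannot be told apart with confidence. Set beside the earlier example, the exchange reads the same on both cores: the same change on two cores in this assay, a 1.1-fold lower number (0.04 log units; within the scatter) from compound 1 to compound 3 and a 1.2-fold higher number (0.09 log units; within the scatter) from compound 2 to compound 4, 1.4-fold (0.13 log units) apart, within the scatter of two such steps. On these two cores, then, the small open-chain dimethylamino group and the larger ring of 3-methylpiperazin-1-yl could not be told apart in this measurement, but two pairs of compounds do not show that this will hold on every core of the series, and a step this small says nothing about why the number stays put or about how the exchange would behave in any other test.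

The compounds shown leave open whether other groups on that aromatic carbon between two ring nitrogen atoms, such as morpholine, unsubstituted piperazine or a simple primary amine, would also leave the number unchanged. Going by these compounds, they also do not separate the several ways in which the core of compound 1 differs from the core of compound 2, so the effect of each of those differences on its own remains unknown.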